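Swapping a Propanoyl Amide for a Methylsulfonyl Group

This account rests on a few compounds, and the source may have more. Where it says the series, first, only, none or still open, it means among the compounds named here.

Measured so far:
Compound 1, `CCS(=O)(=O)N[C@@H]1CCCc2c1cncc2N1Cc2cc(Cl)ccc2C1=O`: 1790 nM in an ADME assay on cells for inhibition of cytochrome P450 11B1, mitochondrial (Homo sapiens), read by HTRF; on this read-out higher numbers stand for weaker inhibition and lower numbers for stronger inhibition.
Compound 2, `CCC(=O)N[C@@H]1CCCc2c1cncc2N1Cc2cc(Cl)ccc2C1=O`: 5210 nM in this assay.

For the measured compounds named here, compound 2 gives the higher of these two numbers; its only neighbour is compound 1, and the step between them is a 2.9-fold higher number from compound 1 to compound 2 (0.46 log units; beyond the scatter), a propanoyl in place of an ethylsulfonyl. Compound 3, `CS(=O)(=O)N[C@@H]1CCCc2c1cncc2N1Cc2cc(Cl)ccc2C1=O`, is not yet measured. Its change from compound 2 is methylsulfonyl in place of propanoyl on an amine nitrogen. Going by the values given here, the one measured step that bears on it is that from compound 1 to compound 2, which runs the opposite way: amide in, sulfonyl out. Compound 3 puts a sulfonyl back, though a methylsulfonyl rather than an ethylsulfonyl, and for that smaller group no measurement exists. A modest fall in number, back toward compound 1, is therefore expected: a 2.6-fold lower number from compound 2 to compound 3 (0.42 log units; beyond the scatter). Compound 3 is estimated at 2000 nM, between 900 nM and 4500 nM.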

Compound 3, half-maximal inhibitory concentration: 9350 nM
Estimate against measurement, compound 3: 4.7-fold (0.67 log units) below, outside the stated range (above it).
By their numbers in this assay, from the lowest: compound 1; then compounds 2 and 3 (each within the scatter of the next).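

In this assay, the sulfonyl group alone does not bring the lower number seen with compound 1: putting hydrogen in place of methyl at the end of the ethylsulfonyl chain gives a 5.2-fold higher number from compound 1 to compound 3 (0.72 log units; beyond the scatter). Exchanging propanoyl for methylsulfonyl on the amine nitrogen gives a 1.8-fold higher number from compound 2 to compound 3 (0.25 log units; within the scatter), so among these three compounds the end of the sulfonyl chain makes a clearer difference than the choice between the amide and the sulfonyl link. Nothing available explains why this small change in the chain shifts the number so much.

On these data alone, it remains open whether a longer chain on the sulfonyl, such as propylsulfonyl, or a ring such as cyclopropylsulfonyl, would lower the number further. Whether the amides follow the same trend is also open, as the shorter acetyl group is not among the compounds shown.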